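Bromo in place of fluoro on compound 2

The source may report more compounds than this note shows. Statements on the series, on what has been measured and on what is new or still open speak of the compounds shown alone.

In a functional assay on HepG2 cells (Homo sapiens) for cytotoxicity, read by MTT assay, with a stated time of 24 h (a lower number here means a stronger inhibitor, a higher number a weaker inhibitor), compound 1 `CN1C/C(=C\c2ccc(C#N)cc2)C(=O)/C(=C/c2ccccc2F)C1` gives 590 nM. Compound 2 `COc1cc(/C=C2\CN(C)C/C(=C\c3ccc(F)cc3)C2=O)cc(OC)c1` gives 6140 nM, the higher of the two numbers and beyond the scatter of compound 1. Compound 3 `COc1cc(/C=C2\CN(C)C/C(=C\c3ccc(Br)cc3)C2=O)cc(OC)c1` carries one change from compound 2: bromo in place of fluoro on an aromatic carbon, para to a large group. For the measured compounds named here, no measured pair isolates this change. In this assay, no shift beyond the scatter is expected, and the estimated step of a 1.4-fold lower number from compound 2 to compound 3 (0.13 log units; within the scatter) is small and leans slightly lower. For compound 3, the estimated value is 4500 nM. The expected range for compound 3 runs from 1800 nM to 10000 nM.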

Compound 3, half-maximal inhibitory concentration: 4840 nM
Compound 3: the middle estimate sits 1.1-fold (0.03 log units) below what was measured; low and high end bracket the measured number.
By their numbers in this assay, from the lowest: compound 1; then compounds 3 and 2 (each within the scatter of the next).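

In this assay, for the compounds shown here, 4-bromophenyl in place of 4-fluorophenyl gives a 1.3-fold lower number from compound 2 to compound 3 (0.10 log units; within the scatter) and is the first matched pair. At this place, para to a large group, the two halogens are therefore not distinguished by this read-out. No supporting measurement bears on why the step is so small. On these data alone, whether an amine or a carboxylic acid here would shift the number beyond the scatter remains open. Compound 1 differs from compound 2 and compound 3 in more than one place, so its lower number cannot be assigned to any single group.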